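Azepan-1-yl replaces dimethylamino in a well-tolerated series

The source may hold more compounds than are shown below. What is called first, only, known or untested is meant among the compounds shown, and "the series" means these compounds.

Compound 1 `Cc1c(Cc2c(F)cccc2F)nc(N(C)C)[nH]c1=O` gives > 89000 nM
Compound 2 `Cc1c(C(C)c2c(F)cccc2F)nc(N(C)C)[nH]c1=O` gives > 17000 nM
Compound 3 `CCC(c1nc(N(C)C)[nH]c(=O)c1C)c1c(F)cccc1F` gives > 81000 nM

In an ADME assay on MT4 cells (Homo sapiens) for cytotoxicity, read by MTT assay, with a stated time of 4 days (a higher number here means that more compound is tolerated, a lower number that less compound is tolerated), all three values are limits, not numbers. Compound 2 stands at > 17000 nM as a limit. Starting from compound 2, the change azepan-1-yl in place of dimethylamino on an aromatic carbon puts azepan-1-yl in place of dimethylamino on an aromatic carbon, between two ring nitrogen atoms, and gives compound 4 `Cc1c(C(C)c2c(F)cccc2F)nc(N2CCCCCC2)[nH]c1=O` as the result. The measured steps a step that the two limits leave unreadable from compound 1 to compound 2 and a step that the two limits leave unreadable from compound 1 to compound 3 and a step that the two limits leave unreadable from compound 2 to compound 3 all alter the saturated chain, not this group, and their sizes cannot be read. No step beyond the scatter is therefore expected in this assay in either direction. The expected change is a step that the limit leaves unreadable from compound 2 to compound 4 as an estimate only. For compound 4 the estimated value is 30000 nM with an expected range from 9000 nM to 100000 nM in this estimate.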

Compound 4, half-maximal cytotoxic concentration: > 72000 nM
Compound 4 ended at the assay's limit (the forecaster's own chance of this, stated with the estimate: 60%); middle value at least 2.4-fold (0.38 log units) away from the limit.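

Compound 2 gives > 17000 nM, which is a limit and not a number. Within the data shown here, compound 4 gives > 72000 nM, also a limit, so no step between compound 2 and compound 4 can be read. The compounds shown leave open at what concentration any of them harms the cells, and whether azepan-1-yl changes that concentration.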